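Adding a Trifluoromethyl Group to the Aryl Ring of Compound 2

The source may hold more compounds than are shown below. What is called first, only, known or untested is meant among the compounds shown, and "the series" means these compounds.

Three compounds have been measured in a functional assay on the whole organism with Mus musculus as the target; on this read-out higher numbers stand for an effect only at larger amounts of compound and lower numbers for an effect already at smaller amounts:

compound 1, `O=c1oc2cccnc2n1CN1CCN(c2cccc(Cl)c2)CC1`, gives 10.5 mg/kg
compound 2, `O=c1oc2cccnc2n1CCCN1CCN(c2ccccc2)CC1`, gives 15.5 mg/kg
compound 3, `COc1ccccc1N1CCN(Cn2c(=O)oc3cccnc32)CC1`, gives > 25 mg/kg

The value of compound 3 is a limit of this assay, not a number. Compound 2 and compound 1 lie within the scatter of each other, so no order can be read between them. Among the compounds with values here, the only step between two measured compounds is an at least 2.3-fold higher number from compound 1 to compound 3 (0.37 log units; beyond the scatter), where the result meets (the limit of > 25 mg/kg in this assay, at which 1 of the 3 values shown sits).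

Compound 4, `O=c1oc2cccnc2n1CCCN1CCN(c2cccc(C(F)(F)F)c2)CC1`, has not been measured. It differs from compound 2 by trifluoromethyl in place of hydrogen on an aromatic carbon. Within the data shown here, the one measured step touches the same aryl ring but swaps a whole substituent pattern rather than adding a single group, so it bears on this change only loosely. Compound 4 is therefore expected to give about 12 mg/kg, with a likely range from 6 mg/kg to 25 mg/kg. The step this estimate implies, a 1.3-fold lower number from compound 2 to compound 4 (0.11 log units; within the scatter), is expected to stay within the scatter.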

Compound 4, dose for half-maximal effect: 22 mg/kg
The estimate for compound 4 lay 1.8-fold (0.26 log units) below the measured number; low and high end bracket the measured number.
By their numbers in this assay, from the lowest: compounds 1, 2 and 4 (each within the scatter of the next, the first and the last beyond it). At a limit, above all of these: compound 3.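

In this assay, trifluoromethyl in place of hydrogen on an aromatic carbon, meta to a large group, gives a 1.4-fold higher number from compound 2 to compound 4 (0.15 log units; within the scatter), so adding these 4 heavy atoms to the aryl ring of compound 2 produces no change that can be read. Within the data shown here, the earlier compounds could not show this, since their only step swaps one whole substituent pattern for another, whereas here a single group is added to an otherwise unsubstituted ring. Nothing among the data shown offers a cause for this result.

Going by these compounds, it remains open whether a different group at this place, such as a nitrile, an amine or a carboxylic acid, would move the number beyond the scatter. On these data alone, it is equally open whether trifluoromethyl on another carbon of the same ring would behave as it does here.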